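The compounds below may be only part of what the source reports. "The series", "measured", "known", "first", "only" and "open" are said of these compounds alone.

Measured in a functional assay on CCRF-CEM cells (Homo sapiens), read by MTT assay, with a stated time of 72 h; a lower number here means a stronger inhibitor, a higher number a weaker inhibitor:
- Compound 1 `COc1ncnc2c1c(-c1cc3ccccc3o1)cn2[C@@H]1O[C@H](CO)[C@@H](O)[C@H]1O`: 5370 nM
- Compound 2 `COc1nc(N)nc2c1c(-c1cccs1)cn2[C@@H]1O[C@H](CO)[C@@H](O)[C@H]1O`: > 20000 nM, a limit and not a number

Compound 2 therefore stands at the limit of this assay, and the record reads (the limit of > 20000 nM in this assay, at which 1 of the 2 values shown sits). Compound 3 `COc1nc(N)nc2c1c(-c1cc3ccccc3o1)cn2[C@@H]1O[C@H](CO)[C@@H](O)[C@H]1O` differs from compound 2 by 1-benzofuran-2-yl in place of thiophen-2-yl on an aromatic carbon. Among the compounds with values here, no measured pair isolates this change, so any forecast rests on little. Compound 1 carries the same 1-benzofuran-2-yl and gives 5370 nM, so a modest move towards stronger inhibition in this assay is expected. The expected change is an at least 1.8-fold lower number from compound 2 to compound 3 (0.25 log units; that floor lies within the scatter), and it may not clear the limit at all. For compound 3 the estimated value is 11000 nM, with an expected range from 4000 nM to 20000 nM.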

Compound 3, half-maximal inhibitory concentration: 12700 nM
The estimate for compound 3 lay 1.2-fold (0.06 log units) below the measured number; measured number inside the range.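

In this assay, 1-benzofuran-2-yl at this position brings compound 3 into the measurable range, while compound 2, with thiophen-2-yl, gives only a limit and not a number: the limit of > 20000 nM in this assay, at which 1 of the 3 values shown sits.

Going by these compounds, the change can therefore be read only as a floor, an at least 1.5-fold lower number from compound 2 to compound 3 (0.19 log units; that floor lies within the scatter), and its true size remains unknown. With 1-benzofuran-2-yl held constant, amino in place of hydrogen on an aromatic carbon gives a modest step that can be read in full, a 2.4-fold higher number from compound 1 to compound 3 (0.37 log units; beyond the scatter).

The compounds shown leave open whether the amino step would carry over to a compound with thiophen-2-yl. They also leave open how phenyl or furan-2-yl at this position would compare with 1-benzofuran-2-yl, and so whether the second ring of 1-benzofuran-2-yl matters.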